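A few compounds are considered here, and "the series" means these few. Any claim that something is new, unique, unknown or untested is made for them only; others in the source may bear on it.

Measured so far in a functional assay on MGC-803 cells (Homo sapiens) for antiproliferative activity, read by MTT assay, with a stated time of 72 h; on this read-out lower numbers stand for stronger inhibition and higher numbers for weaker inhibition:
compound 1 `CCCSc1nc(N/N=C/c2ccccc2Cl)c2nnn(Cc3ccccc3)c2n1` gives 10900 nM
compound 2 `CCCSc1nc(N/N=C(\C)c2ccccc2O)c2nnn(Cc3ccc(O)cc3)c2n1` gives 7680 nM
compound 3 `CCCSc1nc(N/N=C/c2cccc(Cl)c2)c2nnn(Cc3ccccc3)c2n1` gives > 64000 nM

The value for compound 3 is a limit of the assay, not a number (the limit of > 64000 nM in this assay, at which 1 of the 3 values shown sits). Of the two numbers shown, compound 2 holds the lower, with compound 1 nearest and within the scatter of it, so no order between the two is claimed.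

Compound 4 `CCCSc1nc(N/N=C(\C)c2ccccc2O)c2nnn(Cc3cccc(Cl)c3)c2n1` is not yet measured. It differs from compound 2 by 3-chlorophenyl in place of 4-hydroxyphenyl on a saturated chain carbon bound to an aromatic nitrogen. Among the compounds with values here, the one step measured is an at least 5.8-fold higher number from compound 1 to compound 3 (0.76 log units; beyond the scatter), and it concerns the carbon with a double bond to nitrogen, not the saturated chain carbon bound to an aromatic nitrogen that is changed here. Within the data shown here, no measured pair alters the group on that saturated chain carbon, so nothing bears directly on the step from compound 2 to compound 4. Among the measured compounds shown here, with no step to weigh, the expectation in this assay is no change beyond the scatter, direction left open. The estimate for compound 4 is therefore 9000 nM, with a range from 3000 nM to 30000 nM. This estimate amounts to an expected step of a 1.2-fold higher number from compound 2 to compound 4 (0.07 log units; within the scatter).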

Compound 4, half-maximal inhibitory concentration: 6500 nM
For compound 4 the middle estimate is 1.4-fold (0.14 log units) above the measured one; the measured number falls inside the stated range.
By their numbers in this assay, from the lowest: compounds 4, 2 and 1 (each within the scatter of the next). At a limit, above all of these: compound 3.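

In this assay, within the data shown here, the change of 4-hydroxyphenyl to 3-chlorophenyl on a saturated chain carbon bound to an aromatic nitrogen gives a 1.2-fold lower number from compound 2 to compound 4 (0.07 log units; within the scatter) and is the first step read at this position. The hydrogen-bond donor and acceptor counted on 4-hydroxyphenyl leave with this change, and chlorine enters, yet the two numbers cannot be told apart, so in this one pair the hydroxyl is not required for a number of this size. Nothing on hand bears on why the exchange leaves the read-out within the scatter.

The compounds shown leave open whether a different kind of group on that saturated chain carbon, such as a pyridine ring, a phenyl carrying a carboxylic acid, or a longer alkyl chain, would shift the number beyond the scatter. This single step also alters both the substituent and its place on the phenyl ring together, and 4-chlorophenyl or 3-hydroxyphenyl at this position would be needed to read those two apart.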